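Coumarin-anilino series: ethoxy in place of fluoro

The source may report more compounds than this note shows. Statements on the series, on what has been measured and on what is new or still open speak of the compounds shown alone.

Four close relatives share one core. Among the compounds with values here, compound 1 `COc1ccc(-c2c(Nc3ccc(F)cc3)c3ccccc3oc2=O)cc1` is the only member with a number in a functional assay on HCT-116 cells (Homo sapiens) for antiproliferative activity, read by MTT assay, with a stated time of 48 h; on this read-out higher numbers stand for weaker inhibition and lower numbers for stronger inhibition: compound 1 gives 39400 nM, which marks it as a weak inhibitor on this scale. Compound 2 `COc1ccc(-c2c(Nc3ccc(NC(C)=O)cc3)c3ccccc3oc2=O)cc1` carries no number in this assay; its entry reads "not determined" (no result reported). Compound 3 `COc1ccc(-c2c(Nc3ccc(F)cc3)c3ccc(OC)cc3oc2=O)cc1` likewise has no number in this assay, its entry reading "not determined" (no result reported), so compound 3 stands nowhere on the numbers shown, and no step between measured compounds can be drawn to it.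

Compound 4 `CCOc1ccc(Nc2c(-c3ccc(OC)cc3)c(=O)oc3cc(OC)ccc23)cc1` is the next member to be tested in this assay. Its difference from compound 3 is ethoxy in place of fluoro on an aromatic carbon. Within the data shown here, with compound 3 unmeasured, no direction can be read from a step; the only anchor is compound 1 with its 39400 nM, and nothing here argues for a move beyond the scatter from that weak level. Compound 4 is therefore expected to give about 30000 nM in this assay, within a broad range of 8000 nM to 110000 nM.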

Compound 4, half-maximal inhibitory concentration: 33000 nM
Compound 4: the middle estimate sits 1.1-fold (0.04 log units) below what was measured; the measured number falls inside the stated range.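

No step can be read between compound 3 and compound 4 in this assay where only compound 4 has a single number. The compounds shown leave open whether in this assay ethoxy in place of fluoro shifts the value at all. Nothing shown offers evidence bearing on this result.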